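Changing the aryl group on a sulfonamide nitrogen

The source may report more compounds than this note shows. Statements on the series, on what has been measured and on what is new or still open speak of the compounds shown alone.

In a functional assay on HeLa cells (Homo sapiens) for inhibition, read by CCK-8 assay, with a stated time of 72 h (a higher number here means a weaker inhibitor, a lower number a stronger inhibitor), compound 1 (`Cc1ccccc1NS(=O)(=O)c1cccc(CCCCCCNC(=O)/C=C/c2cccnc2)c1`) gives 2.34 nM while compound 2 (`O=C(/C=C/c1cccnc1)NCCCCCCc1cccc(S(=O)(=O)Nc2ccc(F)c(Cl)c2)c1`) gives 385 nM and so holds the higher of the two numbers, marking it as the weaker inhibitor. Compound 3 (`O=C(/C=C/c1cccnc1)NCCCCCCc1cccc(S(=O)(=O)Nc2ccc(C(F)(F)F)cc2)c1`) keeps the shared core and differs from compound 2 in one group: 4-(trifluoromethyl)phenyl in place of 3-chloro-4-fluorophenyl on a sulfonamide nitrogen. Among the compounds with values here, one measured step bears on this place, and it is large: a 160-fold higher number from compound 1 to compound 2 (2.22 log units; beyond the scatter) with 3-chloro-4-fluorophenyl in place of 2-methylphenyl on a sulfonamide nitrogen. That step shows that this group can matter greatly. Yet compound 2 and compound 3 both lack 2-methylphenyl, and no measured step compares groups of their kind. The expected change in this assay is therefore small, a 1.3-fold lower number from compound 2 to compound 3 (0.11 log units; within the scatter) and not expected to lie beyond the scatter in either direction. For compound 3 the estimate is 300 nM with an expected range of 60 nM to 1500 nM as its two ends.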

Compound 3, half-maximal inhibitory concentration: 1450 nM
Compound 3: middle estimate off by 4.8-fold (0.68 log units), on the low side; the range from low to high includes it.
By their numbers in this assay, from the lowest: compound 1; then compound 2; then compound 3.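

In this assay the two replacement groups on the sulfonamide nitrogen are not interchangeable: there is a 3.8-fold higher number from compound 2 to compound 3 (0.58 log units; beyond the scatter) when 3-chloro-4-fluorophenyl gives way to 4-(trifluoromethyl)phenyl. The comparison with 2-methylphenyl widens to a 620-fold higher number from compound 1 to compound 3 (2.79 log units; beyond the scatter) and so exceeds the earlier large step, which leaves compound 1 with the lowest number of the three and both replacements well behind it. No measurement at hand gives a reason for these differences.

Still open, from the compounds shown here alone, is whether other groups on this nitrogen, such as plain phenyl, 2-chlorophenyl or 2-methoxyphenyl, would keep a number close to that of compound 1. A 4-methylphenyl group would help to show whether the low number of compound 1 goes with the methyl group alone or also with where it sits.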